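From ethoxy to 2,2,2-trifluoroethoxy: an untested step

The source may hold more compounds than are shown below. What is called first, only, known or untested is meant among the compounds shown, and "the series" means these compounds.

- Compound 1 `CCOc1cc(-c2ccc3cc[nH]c3c2)cn2c(-c3cc(OC)c(OC)c(OC)c3)nnc12`: 272 nM 
- Compound 2 `CCOc1cc(-c2ccc3c(ccn3C)c2)cn2c(-c3cc(OC)c(OC)c(OC)c3)nnc12`: 210 nM 

Among the measured compounds shown here, in a functional assay on HeLa cells (Homo sapiens) for antiproliferative activity, read by MTT assay, with a stated time of 48 h (a lower number here means a stronger inhibitor, a higher number a weaker inhibitor), compound 2 gives 210 nM and so stands within the scatter of compound 1, the only other compound measured. The next molecule, compound 3 `COc1cc(-c2nnc3c(OCC(F)(F)F)cc(-c4ccc5c(ccn5C)c4)cn23)cc(OC)c1OC`, differs from compound 2 in one group: trifluoromethyl in place of methyl on a saturated chain carbon bound to an oxygen on an aromatic ring. Put another way, ethoxy becomes 2,2,2-trifluoroethoxy.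

For the measured compounds named here, the one measured step, a 1.3-fold lower number from compound 1 to compound 2 (0.11 log units; within the scatter), bears on this only weakly. It is small, within the scatter, and concerns a different change, 1-methyl-1H-indol-5-yl in place of 1H-indol-6-yl. Going by the values given here, no measured pair changes the ethoxy group, so the data give neither a size nor a direction for the new change. No step beyond the scatter is therefore expected in this assay, although the uncertainty is wide. The expected change is a 1.1-fold higher number from compound 2 to compound 3 (0.06 log units; within the scatter) in this estimate. The estimate for compound 3 is 240 nM as the expected value, with 80 nM to 700 nM as its expected range.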

Compound 3, half-maximal inhibitory concentration: 199 nM
For compound 3 the middle estimate is 1.2-fold (0.08 log units) above the measured one; measured number inside the range.
By their numbers in this assay, from the lowest: compounds 3, 2 and 1 (each within the scatter of the next).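

In this assay, among the compounds shown here, placing trifluoromethyl in place of methyl on a saturated chain carbon bound to an oxygen on an aromatic ring gives a 1.1-fold lower number from compound 2 to compound 3 (0.02 log units; within the scatter), the first measured step at this position. Ethoxy can therefore become 2,2,2-trifluoroethoxy, with trifluoromethyl's 4 heavy atoms standing where methyl had 1, and the two compounds still cannot be told apart in this test of cell growth. No supporting measurement accompanies this result, so it stands as an observation without an explanation.

The compounds shown leave open whether a longer chain, an amine or a carboxylic acid could replace the ethoxy group and still give a number within the scatter of compound 2, since this single step covers only one replacement. They also leave open whether 2,2,2-trifluoroethoxy would be tolerated equally with the 1H-indol-6-yl group of compound 1, because the change has been seen only alongside 1-methyl-1H-indol-5-yl and only in these cells.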